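A few compounds are considered here, and "the series" means these few. Any claim that something is new, unique, unknown or untested is made for them only; others in the source may bear on it.

Compound 1 `COc1ccc(-c2cc(=O)c3c(OC)cc(OC)cc3n2C)cc1` has no reported result in a functional assay on HepG2 cells (Homo sapiens) for antiproliferative activity, with a stated time of 72 h (on this read-out higher numbers stand for an effect only at larger amounts of compound and lower numbers for an effect already at smaller amounts), where compound 1 stands at "not determined" (no result reported). Compound 2 `C=CCNC(=O)n1c(-c2ccc(OC)cc2)cc(=O)c2c(OC)cc(OC)cc21` reaches only a limit in this assay, namely > 20000 nM. Compound 3 `COc1ccc(-c2cc(=O)c3c(OC)cc(OC)cc3n2S(=O)(=O)c2ccc(C=O)cc2)cc1` likewise reaches only a limit in this assay, namely > 34400 nM. The step that the two limits leave unreadable from compound 2 to compound 3 cannot be read because its two values sit at the limit of > 20000 nM in this assay, at which 1 of the 3 values shown sits, and (the limit of > 34400 nM in this assay, at which 1 of the 3 values shown sits). Compound 2 thus stands at a limit only; one further value is a limit, and one entry carries no number. Compound 4 `COc1ccc(-c2cc(=O)c3c(OC)cc(OC)cc3n2S(=O)(=O)Cc2ccccc2)cc1` differs from compound 2 in one place: benzylsulfonyl in place of allylcarbamoyl on an aromatic nitrogen. Among the compounds with values here, the only step that bears on this change is a step that the two limits leave unreadable from compound 2 to compound 3, whose size is unreadable, so no readable step in this assay can be foreseen. Compound 4 is therefore expected to sit near the limit too, with an estimated step that the limit leaves unreadable from compound 2 to compound 4. For compound 4 the estimate is 30000 nM, within 10000 nM to 100000 nM.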

Compound 4, half-maximal effective concentration: > 34400 nM
Compound 4: only a limit was reported; the forecaster's own chance of this, stated with the estimate: 85%; middle value at least 1.1-fold (0.05 log units) away from the limit.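

Within the data shown here, no step among compound 2, compound 3 and compound 4 can be read in this assay: each of the three reaches only a limit. Going by these compounds, how the groups on the aromatic nitrogen truly compare remains open.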